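Swapping the Ester-Bearing Phenyl for a Quinoline Arm

The source may hold more compounds than are shown below. What is called first, only, known or untested is meant among the compounds shown, and "the series" means these compounds.

Among the measured compounds shown here, compound 2 `COC(=O)c1ccc(-c2cnc3ncn(C(C)c4cc5cccnc5cc4F)c3n2)cc1F` gives 60.2 nM in a functional assay on NCI-H1993 cells (Homo sapiens) for inhibition, read by CCK-8 assay, with a stated time of 72 h (on this read-out lower numbers stand for stronger inhibition and higher numbers for weaker inhibition), the lowest of the two numbers measured so far. Compound 1 `CC(c1cc2cccnc2cc1F)n1cnc2ncc(-c3cnn(CCO)c3)nc21` gives 175 nM in this assay, and the step of a 2.9-fold lower number from compound 1 to compound 2 (0.46 log units; beyond the scatter) shows that exchanging the group on this aromatic carbon can shift the number modestly. Compound 3 `CC(c1cc2cccnc2cc1F)n1cnc2ncc(-c3cnc4ccccc4c3)nc21` carries a different group at the same place: quinolin-3-yl in place of 3-fluoro-4-(methoxycarbonyl)phenyl on an aromatic carbon. For the measured compounds named here, only that single step bears on this change, and quinolin-3-yl itself has no measured precedent here, so the step of a 1.2-fold higher number from compound 2 to compound 3 (0.10 log units; within the scatter) is expected to be small with an open direction. Compound 3 is therefore estimated at 75 nM, within a range of 25 nM to 250 nM.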

Compound 3, half-maximal inhibitory concentration: 109 nM
Compound 3: the middle estimate sits 1.5-fold (0.16 log units) below what was measured; the measured number falls inside the stated range.
By their numbers in this assay, from the lowest: compounds 2, 3 and 1 (each within the scatter of the next, the first and the last beyond it).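

In this assay quinolin-3-yl gives a 1.8-fold higher number from compound 2 to compound 3 (0.26 log units; within the scatter) and a 1.6-fold lower number from compound 1 to compound 3 (0.21 log units; within the scatter), so at this aromatic carbon it cannot be told apart from either earlier group, even though those two groups differ from each other beyond the scatter. The position therefore accepts a fused two-ring group with neither the ester of compound 2 nor the hydroxyethyl chain of compound 1. No measurement at hand explains these numbers. As far as these compounds go, whether a carboxylic acid in place of that ester, or an amine on the quinolin-3-yl, would move the number beyond the scatter stays open.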